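This account rests on a few compounds, and the source may have more. Where it says the series, first, only, none or still open, it means among the compounds named here.

Compound 1 `Cc1ccccc1Cc1cnc(CCc2ccc(-c3ccccc3C(=O)O)cc2)[nH]1`: 127 nM
Compound 2 `COc1cccc(Cc2cnc(CCc3ccc(-c4ccccc4C(=O)O)cc3)[nH]2)c1`: 4120 nM
Compound 3 `N#Cc1cccc(Cc2cnc(CCc3ccc(-c4ccccc4C(=O)O)cc3)[nH]2)c1`: 812 nM

Three compounds share the core of compound 1 and differ only in the group that sits on a saturated chain carbon bound to an aromatic carbon. In an in vitro functional assay on cells for agonist activity at Bombesin receptor subtype-3 (Homo sapiens), read by luminescence and calcium flux (on this read-out lower numbers stand for an effect already at smaller amounts and higher numbers for an effect only at larger amounts of compound), compound 1 gives 127 nM, the lowest of the three numbers. Compound 2 gives 4120 nM and compound 3 gives 812 nM. The step of a 32-fold higher number from compound 1 to compound 2 (1.51 log units; beyond the scatter) is large, the step of a 6.4-fold higher number from compound 1 to compound 3 (0.81 log units; beyond the scatter) is modest, and between the two newer compounds there is a 5.1-fold lower number from compound 2 to compound 3 (0.71 log units; beyond the scatter). So far, every replacement of the 2-methylphenyl group has moved the number upward, by an amount that depends on which group enters.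

Compound 4 `O=C(O)c1ccccc1-c1ccc(CCc2ncc(Cc3ccc(F)cc3)[nH]2)cc1` has not yet been measured. It differs from compound 1 in one place: 4-fluorophenyl in place of 2-methylphenyl on a saturated chain carbon bound to an aromatic carbon. Both measured steps away from 2-methylphenyl bear on this change, one large and one modest, and neither lowered the number. A higher number than that of compound 1 is therefore expected for compound 4, most likely of modest size, though the spread of the two earlier steps leaves the size uncertain. The expected step is a 4.7-fold higher number from compound 1 to compound 4 (0.67 log units; beyond the scatter). The estimate for compound 4 in this assay is 600 nM, with a range from 150 nM to 3000 nM.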

Compound 4, half-maximal effective concentration: 1600 nM
Estimate against measurement, compound 4: 2.7-fold (0.43 log units) below, within the range that was stated.
By their numbers in this assay, from the lowest: compound 1; then compounds 3 and 4 (each within the scatter of the next); then compound 2.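

In this assay, the change to 4-fluorophenyl gives a 13-fold higher number from compound 1 to compound 4 (1.10 log units; beyond the scatter) even though this group has the same number of heavy atoms as 2-methylphenyl and, like it, is counted with no hydrogen-bond donors or acceptors, so a match in these counts does not keep the number of compound 1. Among the replacements, a 2.0-fold higher number from compound 3 to compound 4 (0.29 log units; within the scatter) leaves the 3-cyanophenyl and 4-fluorophenyl groups indistinguishable, whereas a 2.6-fold lower number from compound 2 to compound 4 (0.41 log units; beyond the scatter) separates the 4-fluorophenyl group from the 3-methoxyphenyl group, and all three replacements now stand on the higher side of compound 1 at this position. No measurement shown here accounts for the difference between these groups.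

The compounds shown do not reveal whether the lower number of compound 1 follows from the methyl group itself or from where it sits, a question that 4-methylphenyl, 2-fluorophenyl and unsubstituted phenyl groups would address. They also leave open how this position would respond to a group of another kind, such as an amine or a longer chain in place of the substituted phenyl ring.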